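Chain ends on the shared core: compound 4

This account rests on a few compounds, and the source may have more. Where it says the series, first, only, none or still open, it means among the compounds named here.

Values in a functional assay on HT cells (Homo sapiens) for antiproliferative activity, read by fluorescence, with a stated time of 72 h; on this read-out higher numbers stand for weaker inhibition of growth and lower numbers for stronger inhibition of growth:
compound 1 `CC(C)c1n[nH]c2c(NCc3ccc(-c4ccccn4)cc3)nc(SCC(O)CN3CCNCC3)nc12` gives 332 nM
compound 2 `CC(O)CSc1nc(NCc2ccc(-c3ccccn3)cc2)c2[nH]nc(C(C)C)c2n1` gives 62 nM
compound 3 `CC(C)c1n[nH]c2c(NCc3ccc(-c4ccccn4)cc3)nc(SCCNC(=N)N)nc12` gives 390 nM

In this assay compound 3 sits level with compound 1 and well above compound 2. The numbers show a 1.2-fold higher number from compound 1 to compound 3 (0.07 log units; within the scatter), and also a 6.3-fold higher number from compound 2 to compound 3 (0.80 log units; beyond the scatter).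

The next structure is compound 4 `CNCCSc1nc(NCc2ccc(-c3ccccn3)cc2)c2[nH]nc(C(C)C)c2n1`. The change is one carbon atom in place of a group of 3 heavy atoms (1 carbon, 2 nitrogen; no ring), on an amine nitrogen, so a methyl now stands on an amine nitrogen whose other neighbours are: saturated chain carbon.

For the measured compounds named here, no measured step makes this exact change, so the evidence is indirect. Compound 1 and compound 3 both carry nitrogen at the chain end, and their very different end groups gave only a 1.2-fold higher number from compound 1 to compound 3 (0.07 log units; within the scatter). Compound 4 also keeps nitrogen there. The larger steps, a 5.4-fold lower number from compound 1 to compound 2 (0.73 log units; beyond the scatter) and a 6.3-fold higher number from compound 2 to compound 3 (0.80 log units; beyond the scatter), both involve compound 2, whose chain end has no nitrogen. Three compounds are a thin basis, and compound 2 remains a possible guide if the chain end matters in another way.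

No step beyond the scatter is therefore expected, with at most a slight drift towards lower numbers. The expected step is a 1.4-fold lower number from compound 3 to compound 4 (0.14 log units; within the scatter). For compound 4 the estimated value is 280 nM, with an expected range from 100 nM to 650 nM.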

Compound 4, concentration for 50% growth inhibition: 56 nM
Compound 4: the middle estimate sits 5.0-fold (0.70 log units) above what was measured; measured number outside the range, below it.
By their numbers in this assay, from the lowest: compounds 4 and 2 (each within the scatter of the next); then compounds 1 and 3 (each within the scatter of the next).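

In this assay, nitrogen at the chain end does not by itself set the level: with methyl in place of the group of 3 heavy atoms on the amine nitrogen, the series shows a 7.0-fold lower number from compound 3 to compound 4 (0.84 log units; beyond the scatter), and replacing the whole 1-hydroxy-2-(piperazin-1-yl)ethyl end with (methylamino)methyl gives a 5.9-fold lower number from compound 1 to compound 4 (0.77 log units; beyond the scatter). The chain end of compound 2 has no nitrogen and that of compound 4 does, yet the step shows a 1.1-fold lower number from compound 2 to compound 4 (0.04 log units; within the scatter), so the presence or absence of nitrogen does not separate these compounds from compound 1 and compound 3 as the earlier set allowed. Nothing measured on these compounds accounts for these steps.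

On these data alone, it remains open whether a primary amine, a dimethylamino group or a carboxylic acid at this chain end would stay level with compound 2 and compound 4 or fall with compound 1 and compound 3. A longer chain carrying the same methylamino end would show whether the distance from the sulfur matters as well as the end group itself.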